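This account rests on a few compounds, and the source may have more. Where it says the series, first, only, none or still open, it means among the compounds named here.

Compound 1 `CC(C)c1noc(N2CCC(Oc3cc(N4CCc5cc(N6CCCCC6=O)ccc54)ncn3)CC2)n1` stands highest of the two numbers in a physicochemical assay for lipophilicity, measured as octanol-water partition, at pH 7.4 (a higher number here means a more lipophilic compound, a lower number a more polar compound), where compound 1 gives 3.8. Compound 3 `CC(C)c1noc(N2CCC(Oc3cc(N4CCc5cc(S(=O)(=O)CCO)ccc54)ncn3)CC2)n1` is the unmeasured analogue: (2-hydroxyethyl)sulfonyl in place of 2-oxopiperidin-1-yl on an aromatic carbon. Among the measured compounds shown here, the one step that bears on this is the related sulfinyl change, a number 1.10 log units lower from compound 1 to compound 2 (beyond the scatter), with compound 2 `CC(C)c1noc(N2CCC(Oc3cc(N4CCc5cc([S+]([O-])CCO)ccc54)ncn3)CC2)n1` giving 2.7 in this assay. A step of comparable size and direction, downward and beyond the scatter, is therefore expected for the (2-hydroxyethyl)sulfonyl, a number 0.90 log units lower from compound 1 to compound 3 (beyond the scatter). For compound 3 the estimate in this assay is 2.9, within 2.4 to 3.4.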

Compound 3, distribution coefficient: 2.7
Compound 3: the middle estimate sits 0.20 log units above what was measured; low and high end bracket the measured number.
By their numbers in this assay, from the lowest: compounds 2 and 3 (each within the scatter of the next); then compound 1.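

In this assay, the large downward step is not confined to the sulfinyl group: (2-hydroxyethyl)sulfonyl in place of 2-oxopiperidin-1-yl on this aromatic carbon gives a number 1.10 log units lower from compound 1 to compound 3 (beyond the scatter). Changing sulfinyl to sulfonyl on the same chain gives no change at the digits printed from compound 2 to compound 3 (within the scatter), so this read-out does not separate the two sulfur groups at this position. Nothing available explains either step.

Still open, going by these compounds, is how much of the step depends on the terminal hydroxyl rather than the sulfonyl group. A methylsulfonyl group or a longer hydroxyalkyl chain at this position would address that.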